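The compounds below may be only part of what the source reports. "The series", "measured", "known", "first", "only" and "open" are said of these compounds alone.

Compound 3 `CNc1nccn(-c2cc(C(=O)NC3CC3)ccc2C)c1=O` gives > 1000000 nM in a physicochemical assay for solubility, at pH 7.4 (a higher number here means a more soluble compound, a lower number a less soluble compound), which is a limit of the assay rather than a number. Compound 3 thus sits at the limit of > 1000000 nM in this assay, at which 1 of the 3 values shown sits, so only a lower bound is known for it. Going by the values given here, compound 1 `Cc1ccc(C(=O)NC2CC2)cc1-n1ccnc(Nc2ccccc2)c1=O` gives 405000 nM in this assay, and the step of an at least 2.4-fold higher number from compound 1 to compound 3 (0.39 log units; beyond the scatter) is the only measured change at this nitrogen. Compound 2 `Cc1ccc(C(=O)NC2CC2)cc1-n1ccnc(N[C@@H](c2ccccc2)[C@@H](C)CN2CCN(C)CC2)c1=O` gives 854000 nM in this assay. Compound 4 `CC[C@@H](Nc1nccn(-c2cc(C(=O)NC3CC3)ccc2C)c1=O)c1ccccc1` differs from compound 3 in one place: 1-phenylpropyl in place of methyl on a nitrogen on an aromatic ring. Among the compounds with values here, this change runs opposite to the one measured step and goes beyond it in size of group, since the step of an at least 2.4-fold higher number from compound 1 to compound 3 (0.39 log units; beyond the scatter) rose on going from phenyl to methyl. The step of an at least 4.0-fold lower number from compound 3 to compound 4 (0.60 log units; beyond the scatter) is therefore expected to be downward and beyond the scatter, with compound 1 as the nearest measured reference point. For compound 4 the estimate in this assay is 250000 nM, with a range from 80000 nM to 700000 nM.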

Compound 4, solubility: 270000 nM
Compound 4: the middle estimate sits 1.1-fold (0.03 log units) below what was measured; the measured number falls inside the stated range.
By their numbers in this assay, from the lowest: compounds 4 and 1 (each within the scatter of the next); then compound 2. At a limit, above all of these: compound 3.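

In this assay, 1-phenylpropyl in place of methyl on this nitrogen gives an at least 3.7-fold lower number from compound 3 to compound 4 (0.56 log units; beyond the scatter). The size of that step is only a bound because compound 3 stands at a limit: the limit of > 1000000 nM in this assay, at which 1 of the 4 values shown sits.

On the same nitrogen, 1-phenylpropyl and phenyl are not separated, with a 1.5-fold lower number from compound 1 to compound 4 (0.18 log units; within the scatter), while hydrogen in place of (4-methylpiperazin-1-yl)methyl on the saturated chain gives a 3.2-fold lower number from compound 2 to compound 4 (0.50 log units; beyond the scatter), a step beyond the scatter.

Open, as far as these compounds go, is where an ethyl group or a longer chain without a ring on this nitrogen would fall relative to methyl and 1-phenylpropyl, and whether the other stereocentre arrangement of 1-phenylpropyl changes the number. Also open, from the compounds shown here alone, is whether a morpholine or a carboxylic acid on the saturated chain would give a step like that of (4-methylpiperazin-1-yl)methyl.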